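A few compounds are considered here, and "the series" means these few. Any claim that something is new, unique, unknown or untested is made for them only; others in the source may bear on it.

The compounds measured so far:

Compound 1, `O=C(Nc1cccc(C(F)(F)F)c1)c1c(O)nnn1Cc1ccc(OC(F)(F)F)cc1`: in an ADME assay on isolated protein for inhibition of cytochrome c oxidase subunit 2 (Homo sapiens), read by ELISA (a lower number here means a stronger inhibitor, a higher number a weaker inhibitor), compound 1 gives > 100000 nM, which is a limit of the assay and not a number.
Compound 2, `Oc1noc2cccc(Nc3cccc(C(F)(F)F)c3)c12`: in this assay compound 2 gives > 100000 nM, again only a limit.
Compound 3, `Oc1noc2ccc(Nc3cccc(C(F)(F)F)c3)cc12`: in this assay compound 3 gives > 100000 nM, also a limit.

Compound 2 therefore has no number of its own in this assay, only a limit, and the same holds for the two other compounds: all of them sit at the limit of > 100000 nM in this assay, at which 3 of the 3 values shown sit. Among the measured compounds shown here, no two of the measured compounds differ from each other in a single place, so no step between measured compounds can be read off, and the three shared limits give no direction in which a change might move the read-out.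

Compound 4, `Oc1noc2cccc(Nc3cc(C(F)(F)F)cc(C(F)(F)F)c3)c12`, has not yet been measured. It differs from compound 2 by trifluoromethyl in place of hydrogen on an aromatic carbon. With nothing but limits among the measured compounds, the expectation for this change is no step beyond the usual scatter, and most likely a fourth limit rather than a number. The step that this estimate implies is a step that the limit leaves unreadable from compound 2 to compound 4. For compound 4 the expected value in this assay is 150000 nM, with a range from 50000 nM to 500000 nM.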

Compound 4, half-maximal inhibitory concentration: > 100000 nM
Compound 4: only a limit was reported; the forecaster's own chance of this, stated with the estimate: 85%; the middle value lies beyond the limit too.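

Compound 2 and compound 4 each give only a limit of the assay and not a number, so no step can be read for trifluoromethyl in place of hydrogen: the limit of > 100000 nM in this assay, at which 4 of the 4 values shown sit. The compounds shown leave open what size of step this change makes in this assay and which change, if any, would give a read-out with a number.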